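Bromo to hydroxy on the ethoxy chain

The compounds below may be only part of what the source reports. "The series", "measured", "known", "first", "only" and "open" are said of these compounds alone.

Compound 1 `CCOC(=O)n1c2ccc([N+](=O)[O-])cc2c(=O)n1Cc1ccccc1`: 122000 nM
Compound 2 `O=[N+]([O-])c1ccc2nn(Cc3ccccc3)c(OCCBr)c2c1`: > 256000 nM (a limit)

Both compounds were tested in an ADME assay on L929 cells (Mus musculus) for cytotoxicity, read by resazurin assay, with a stated time of 48 h; on this read-out lower numbers stand for higher toxicity in this test and higher numbers for lower toxicity in this test. In this assay compound 1 gives 122000 nM, a measured number. Compound 2 gives > 256000 nM, which is a limit of the assay and not a number. Its place on the scale is the limit of > 256000 nM in this assay, at which 1 of the 2 values shown sits.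

Compound 3 `O=[N+]([O-])c1ccc2nn(Cc3ccccc3)c(OCCO)c2c1` has not yet been measured. It differs from compound 2 in one place: hydroxy in place of bromo on a saturated chain carbon, two bonds along the chain from an oxygen on an aromatic ring. This puts hydroxy in place of bromo on a saturated chain carbon, two bonds along the chain from an oxygen on an aromatic ring, so that 2-bromoethoxy becomes 2-hydroxyethoxy. Among the measured compounds shown here, no measured pair here shows what such a change does. No step beyond the usual scatter is therefore expected in this assay. The expectation rests on compound 2 and its limit of > 256000 nM. The estimated change is a step that the limit leaves unreadable from compound 2 to compound 3, and a report of only a limit is expected to be more likely than not. For compound 3 the estimated value is 300000 nM, with an expected range of 130000 nM to 600000 nM.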

Compound 3, concentration lethal to 50% of the cells: > 256000 nM
Compound 3 ended at the assay's limit; the forecaster's own chance of this, stated with the estimate: 65%; the middle value does not contradict the limit.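

Compound 2 and compound 3 both end at a limit of this assay and not at a number, so the change from bromo to hydroxy yields no readable step between them: the limit of > 256000 nM in this assay, at which 2 of the 3 values shown sit.

The compounds shown leave open whether 2-bromoethoxy and 2-hydroxyethoxy differ at all in this assay, and, if they do, in which direction and by how much.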